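Chloro-to-hydrogen step in a chromone series on IMR-32 cells

The compounds below may be only part of what the source reports. "The series", "measured", "known", "first", "only" and "open" are said of these compounds alone.

Measured so far:
compound 1, `O=c1c(C(=S)Nc2ccccc2)coc2cc(Cl)ccc12`, 92700 nM
compound 2, `O=c1c(C2N=C(c3ccccc3)SS2)coc2ccc(Cl)cc12`, 10000 nM
compound 3, `O=c1c(C2N=C(c3ccccc3)SS2)coc2ccccc12`, 16500 nM

The readout is a functional assay on IMR-32 cells (Homo sapiens) for inhibition, read by sulforhodamine B assay, with a stated time of 48 h; a higher number here means a weaker inhibitor, a lower number a stronger inhibitor. Compound 1 gives the highest of the three numbers, compound 2 the lowest. The difference between the core of compound 1 and the core of compound 2 is not broken down here. Compound 2 and compound 3 differ in one place only: hydrogen in place of chloro on an aromatic carbon, which gave a 1.7-fold higher number from compound 2 to compound 3 (0.22 log units; within the scatter).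

Compound 4, `O=c1c(C(=S)Nc2ccccc2)coc2ccccc12`, has not been measured. It differs from compound 1 in exactly the same way: hydrogen in place of chloro on an aromatic carbon. The place lines for the two changes are the same word for word, so this is the same change, made once on each core; it occurs twice among the compounds shown. Because a 1.7-fold higher number from compound 2 to compound 3 (0.22 log units; within the scatter) was within the scatter, the expectation for compound 4 is a step of similar size, a 1.6-fold higher number from compound 1 to compound 4 (0.21 log units; within the scatter), resting on that single precedent. Compound 4 is therefore estimated at 150000 nM, with a range from 70000 nM to 350000 nM.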

Compound 4, half-maximal inhibitory concentration: 95800 nM
The estimate for compound 4 lay 1.6-fold (0.19 log units) above the measured number, within the range that was stated.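

In this assay, hydrogen in place of chloro on an aromatic carbon gave a 1.0-fold higher number from compound 1 to compound 4 (0.01 log units; within the scatter), so this step, like the earlier one, stays within the scatter. Set side by side, the two steps do not differ, and on these two cores the change carries over without a detectable difference: the same change on two cores in this assay, a 1.7-fold higher number (0.22 log units; within the scatter) from compound 2 to compound 3 and a 1.0-fold higher number (0.01 log units; within the scatter) from compound 1 to compound 4, 1.6-fold (0.20 log units) apart, within the scatter of two such steps. For the compounds shown here, this shows only that the change is equally silent on two cores in this one assay; it does not show that chloro is unimportant on any other core, and two pairs cannot establish a rule for the series.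

Open, going by these compounds, is whether another group on that aromatic carbon, such as an amine, a methoxy group or a carboxylic acid, would give a step beyond the scatter, since only chloro and hydrogen appear there. Going by these compounds alone, also open is what separates the core of compound 1 from the core of compound 2, as no single-place step links them.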